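The source may hold more compounds than are shown below. What is called first, only, known or untested is meant among the compounds shown, and "the series" means these compounds.

In a functional assay on K562 cells (Homo sapiens) for cytotoxicity, read by trypan blue exclusion, with a stated time of 96 h (a higher number here means a weaker inhibitor, a lower number a stronger inhibitor), three compounds have been measured so far. Compound 1 (`COc1ccc(/C=C/S(=O)(=O)Cc2ccc(OC)c(N)c2)c(OC)c1`) gives 500 nM, compound 2 (`COc1cc(OC)c(/C=C/S(=O)(=O)Cc2ccc(OC)c([N+](=O)[O-])c2)c(OC)c1`) gives 2500 nM, and compound 3 (`COc1cc(OC)c(/C=C/S(=O)(=O)Cc2ccc(OC)c(N)c2)c(OC)c1`) gives 2.5 nM. Compound 3 therefore holds the lowest number of the three, and its gaps to the other two lie beyond the scatter. The next compound, compound 4 (`COc1ccc(CS(=O)(=O)/C=C/c2c(OC)cc(OCCCC(=O)O)cc2OC)cc1N`), shares its core with compound 3 but carries 3-carboxypropoxy where compound 3 has a methoxy: 2-carboxyethyl in place of hydrogen on a saturated chain carbon bound to an oxygen on an aromatic ring.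

Within the data shown here, two measured steps bear on this change, though only indirectly. The first, a 200-fold lower number from compound 1 to compound 3 (2.30 log units; beyond the scatter), comes with methoxy in place of hydrogen on an aromatic carbon. The second, a 1000-fold lower number from compound 2 to compound 3 (3.00 log units; beyond the scatter), comes with amino in place of nitro on an aromatic carbon. Neither tests a chain on an oxygen, so the data give no direct size for this change. They do show that both single-site departures measured from compound 3 end at far higher numbers. A move towards a higher number is therefore expected in this assay, smaller than those two steps but clearly beyond the scatter. The expected move is a 40-fold higher number from compound 3 to compound 4 (1.60 log units; beyond the scatter). For compound 4 the estimated value is 100 nM, with an expected range from 10 nM to 1500 nM.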

Compound 4, half-maximal inhibitory concentration: 20000 nM
Beside the measured number, compound 4's estimate is 200-fold (2.30 log units) below it; the whole stated range lies below it.
By their numbers in this assay, from the lowest: compound 3; then compound 1; then compound 2; then compound 4.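

In this assay, among these compounds, the step of an 8000-fold higher number from compound 3 to compound 4 (3.90 log units; beyond the scatter) is the first to test a chain built out from the oxygen, since the earlier steps changed only groups on aromatic carbons. Among the compounds shown here, it shows that this position does not tolerate the swap of methoxy for 3-carboxypropoxy, and the step is larger even than a 1000-fold lower number from compound 2 to compound 3 (3.00 log units; beyond the scatter), the largest of the earlier steps. Nothing measured here explains why the number rises so steeply, so the size of the step stands on its own.

What remains open is which part of the new group matters, since 2-carboxyethyl adds both chain length and a carboxylic acid in a single change, and the compounds shown do not separate the two. A plain propoxy chain, a methyl ester of the acid or an amine at the chain end could each show whether a number near the 2.5 nM of compound 3 can be kept at this position, and the same question stands for a chain on either of the other methoxy groups of that ring.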